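The source may hold more compounds than are shown below. What is called first, only, known or untested is meant among the compounds shown, and "the series" means these compounds.

Compounds measured so far in a functional assay on RAW264.7 cells (Mus musculus) for inhibition, read by fluorescence, with stated times of 1 h, 24 h and 30 min; on this read-out lower numbers stand for stronger inhibition and higher numbers for weaker inhibition:

Compound 1, `O=C(/C=C/c1cccc(F)c1)c1ccccc1`, gives > 10000 nM, which is a limit of this assay and not a number.
Compound 2, `O=C(/C=C/c1cccc(F)c1)c1cccc(O)c1`, gives > 10000 nM, again a limit rather than a number.
Compound 3, `O=C(/C=C/c1ccc(F)cc1)c1ccccc1`, gives > 10000 nM, also a limit.

Compound 1 and compound 3 share the same atoms joined differently; the difference between the two cores is not broken down here. Compound 2 arises from compound 1 by hydroxy in place of hydrogen on an aromatic carbon, and the resulting step, a step that the two limits leave unreadable from compound 1 to compound 2, cannot be sized because of the limit of > 10000 nM in this assay, at which 3 of the 3 values shown sit.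

Compound 4, `O=C(/C=C/c1ccc(F)cc1)c1ccc(O)cc1`, is not yet measured in this assay. It arises from compound 3 by hydroxy in place of hydrogen on an aromatic carbon. This is the same kind of change as that from compound 1 to compound 2, but not the same: in one case the hydroxy sits meta to a large group, in the other para to a large group.

Since the earlier step is unreadable, the expected step that the limit leaves unreadable from compound 3 to compound 4 is taken as small, resting on compound 3 at > 10000 nM. Compound 4 is therefore estimated at 15000 nM, within 4000 nM to 60000 nM.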

Compound 4, half-maximal inhibitory concentration: > 10000 nM
Compound 4 ended at the assay's limit; the forecaster's own chance of this, stated with the estimate: 75%; the middle value lies beyond the limit too.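

In this assay, no step can be read from compound 3 to compound 4, and the new result gives no reading of the change from compound 1 to compound 2 either, because all four compounds sit at one limit: the limit of > 10000 nM in this assay, at which 4 of the 4 values shown sit.

The compounds shown leave open whether hydroxy in place of hydrogen on an aromatic carbon alters inhibition at all, and how strongly any of the four compounds inhibits.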